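The compounds below may be only part of what the source reports. "The series", "measured", "known", "first", "only" and "open" are said of these compounds alone.

The measured compounds and their values in a functional assay for antagonist activity at Vanilloid receptor (Rattus norvegicus); on this read-out lower numbers stand for stronger inhibition and higher numbers for weaker inhibition:

compound 1 `CCCS(=O)(=O)Nc1ccc(C/N=C(\S)NCc2ccc(C(C)(C)C)cc2)cc1`: 4500 nM
compound 2 `CCCCS(=O)(=O)Nc1ccc(C/N=C(\S)NCc2ccc(C(C)(C)C)cc2)cc1`: 4100 nM
compound 3 `CC(C)S(=O)(=O)Nc1ccc(C/N=C(\S)NCc2ccc(C(C)(C)C)cc2)cc1`: 3800 nM

Compound 3 gives the lowest of the three numbers, yet the steps of a 1.2-fold lower number from compound 1 to compound 3 (0.07 log units; within the scatter) and a 1.1-fold lower number from compound 2 to compound 3 (0.03 log units; within the scatter) both lie within the scatter, as does the step of a 1.1-fold lower number from compound 1 to compound 2 (0.04 log units; within the scatter), so the three compounds are not separated by this assay. Compound 4 `CN(C)S(=O)(=O)Nc1ccc(C/N=C(\S)NCc2ccc(C(C)(C)C)cc2)cc1` is not yet measured; it differs from compound 3 by dimethylamino in place of isopropyl on a sulfonyl sulfur. For the measured compounds named here, the steps that bear on this change are the two that altered the group on the sulfonyl sulfur, namely a 1.2-fold lower number from compound 1 to compound 3 (0.07 log units; within the scatter) and a 1.1-fold lower number from compound 2 to compound 3 (0.03 log units; within the scatter), and neither moved the number beyond the scatter. Going by the values given here, no measured step, however, replaces a carbon group on the sulfonyl sulfur with a nitrogen-linked one, so the bearing is indirect. On this basis no step beyond the scatter is expected for compound 4 in this assay. Compound 4 is therefore estimated at 4000 nM, with a range from 1500 nM to 11000 nM. For compound 4 the expected step is a 1.1-fold higher number from compound 3 to compound 4 (0.02 log units; within the scatter).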

Compound 4, half-maximal inhibitory concentration: 14600 nM
Compound 4: middle estimate off by 3.7-fold (0.56 log units), on the low side; measured number outside the range, above it.
By their numbers in this assay, from the lowest: compounds 3, 2 and 1 (each within the scatter of the next); then compound 4.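

In this assay, the position on the sulfonyl sulfur turned out not to be indifferent: propyl, butyl and isopropyl stayed within the scatter of one another, but dimethylamino gave a 3.8-fold higher number from compound 3 to compound 4 (0.58 log units; beyond the scatter), and likewise a 3.6-fold higher number from compound 2 to compound 4 (0.55 log units; beyond the scatter) and a 3.2-fold higher number from compound 1 to compound 4 (0.51 log units; beyond the scatter). Isopropyl and dimethylamino have the same count of heavy atoms, so this position separates two groups that differ in one carbon exchanged for a nitrogen, and all three carbon-linked groups fall on the stronger side of that step. Nothing available explains this loss of inhibition.

Dimethylamino is the only nitrogen-linked group shown, so it remains open whether the step belongs to nitrogen linkage generally or to this group alone. A methylamino or pyrrolidinyl group on the sulfonyl sulfur would bear on that question.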